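Cytotoxicity notes: phenoxy to hydroxy on compound 2

The source may report more compounds than this note shows. Statements on the series, on what has been measured and on what is new or still open speak of the compounds shown alone.

compound 1 `CCOC(=O)CCCCCOc1cccc(CN(C(=O)c2ccc(-c3ccncc3)cc2)C(C)C)c1` — > 26000 nM
compound 2 `CCOC(=O)CCCCCOc1cccc(CN(C(=O)c2ccc(-c3cccc(Oc4ccccc4)c3)cc2)C(C)C)c1` — > 19600 nM

In an ADME assay on BJ cells (Homo sapiens) for cytotoxicity, read by CellTiter-Glo and resazurin assay, with a stated time of 72 h (a higher number here means that more compound is needed for the effect, a lower number that less compound is needed), compound 1 gives > 26000 nM, which is a limit of the assay and not a number. Compound 2 gives > 19600 nM, likewise a limit. Compound 2 therefore stands at one of the two limits seen in this assay, with no number that would place it against compound 1 (the limit of > 19600 nM in this assay, at which 1 of the 2 values shown sits, (the limit of > 26000 nM in this assay, at which 1 of the 2 values shown sits)).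

Compound 3 `CCOC(=O)CCCCCOc1cccc(CN(C(=O)c2ccc(-c3cccc(O)c3)cc2)C(C)C)c1` differs from compound 2 by hydrogen in place of phenyl on an oxygen on an aromatic ring. Within the data shown here, no measured pair isolates such a change, and both measured compounds sit at limits, so no direction can be read from them. The step is expected to be none beyond the scatter, a step that the limit leaves unreadable from compound 2 to compound 3, with compound 3 most likely reported again as a limit. Compound 3 is estimated at 30000 nM in this assay, within a range from 10000 nM to 100000 nM.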

Compound 3, half-maximal effective concentration: > 26000 nM
Compound 3 was reported as a limit; the forecaster's own chance of this, stated with the estimate: 85%; the middle value is on the limit's open side.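

No new step can be read: compound 1, compound 2 and compound 3 all stand as limits in this assay, not as numbers. The compounds shown leave open at what concentration any of them reaches the half-maximal effect, and whether phenoxy to hydroxy alters it.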